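A few compounds are considered here, and "the series" means these few. Any claim that something is new, unique, unknown or untested is made for them only; others in the source may bear on it.

Compound 2 `O=C(Nc1c(F)cc(F)cc1F)N(Cc1ccc(-c2cccs2)cc1)C1CCCCCC1`, in an assay on microsomes from intestine for inhibition of acyl-CoA:cholesterol acyltransferase (Oryctolagus cuniculus); on this read-out lower numbers stand for stronger inhibition and higher numbers for weaker inhibition: 18 nM
Compound 3 `Cc1cc(C)c(NC(=O)N(Cc2ccc(-c3cccs3)cc2)C2CCCCCC2)c(C)c1`, in this assay: 22 nM
Compound 1 `Cc1cc(C)c(NC(=O)N(Cc2ccc(-c3ccccc3)o2)C2CCCCCC2)c(C)c1`, in this assay: 44 nM

Compound 2 stands at the lowest of the three numbers in this assay. Its nearest neighbour is compound 3, reached by a 1.2-fold higher number from compound 2 to compound 3 (0.09 log units; within the scatter), a step that lies within the scatter. Compound 1 is the furthest away, and the gap from compound 2 to compound 1 lies beyond the scatter.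

Compound 4 `O=C(Nc1c(F)cc(F)cc1F)N(Cc1ccc(-c2ccsc2)cc1)C1CCCCCC1` has not yet been measured. It differs from compound 2 in one place: thiophen-3-yl in place of thiophen-2-yl on an aromatic carbon. For the measured compounds named here, none of the measured steps bears directly on this change. Going by the values given here, the one measured step, from compound 2 to compound 3, alters the group on the amide-type nitrogen, not the thiophene, and it stayed within the scatter. Compound 1 and compound 3 differ in more than one place, so their values only show that the two lie beyond the scatter of each other.

Among the compounds with values here, with no measured step on the thiophene attachment, the number for compound 4 in this assay is expected to be close to that of compound 2, with the estimated step of a 1.4-fold higher number from compound 2 to compound 4 (0.14 log units; within the scatter) not beyond the scatter. Compound 4 is therefore estimated at 25 nM, within a range from 10 nM to 70 nM.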

Compound 4, half-maximal inhibitory concentration: 23 nM
For compound 4 the middle estimate is 1.1-fold (0.04 log units) above the measured one, and the stated range covers the measured number.
By their numbers in this assay, from the lowest: compounds 2, 3, 4 and 1 (each within the scatter of the next, the first and the last beyond it).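

Placing thiophen-3-yl in place of thiophen-2-yl, on an aromatic carbon para to a large group, gives a 1.3-fold higher number from compound 2 to compound 4 (0.11 log units; within the scatter) in this assay. For the compounds shown here, this is the first measured change at this position, and with the 2,4,6-trifluorophenyl group on the amide-type nitrogen, this assay does not separate the two points of thiophene attachment, which share the same atoms and the same counts of donors and acceptors. Nothing available accounts for the two attachments reading alike.

On these data alone, what remains open is how this position responds to a ring of another kind, such as pyridin-3-yl, or to a small substituent such as a methyl group on the thiophene. Also open, as far as these compounds go, is whether thiophen-3-yl behaves the same way with the 2,4,6-trimethylphenyl group on the amide-type nitrogen.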